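The compounds below may be only part of what the source reports. "The series", "measured", "known", "first", "only" and "open" are said of these compounds alone.

Four compounds from one series are compared in a functional assay on A549 cells (Homo sapiens) for cytotoxicity, read by MTT assay, with a stated time of 48 h; on this read-out lower numbers stand for stronger inhibition and higher numbers for weaker inhibition. Compound 1 `COC(=O)c1ccc2[nH]cc(C3(c4c[nH]c5ccc(C(=O)OC)cc45)C(=O)Nc4ccccc43)c2c1` gives 750 nM in this assay. Compound 3 `COC(=O)c1ccc2[nH]cc(C3(c4c[nH]c5ccc(C(=O)OC)cc45)C(=O)Nc4ccc(Cl)cc43)c2c1` carries a chloro group where compound 1 carries a hydrogen, and in this assay compound 3 gives 71500 nM. The change from compound 3 to compound 1 is hydrogen in place of chloro on an aromatic carbon and brings a 95-fold lower number from compound 3 to compound 1 (1.98 log units; beyond the scatter). Compound 2 `O=C1Nc2ccc(Cl)cc2C1(c1c[nH]c2ccc(Br)cc12)c1c[nH]c2ccc(Br)cc12` carries the same chloro group as compound 3, but the rest of its structure differs; the difference between the two cores is not broken down here. In this assay compound 2 gives > 100000 nM, which is a limit of the assay rather than a measured number (the limit of > 100000 nM in this assay, at which 1 of the 3 values shown sits). Compound 4 `O=C1Nc2ccccc2C1(c1c[nH]c2ccc(Br)cc12)c1c[nH]c2ccc(Br)cc12` has not yet been measured. It stands to compound 2 as compound 1 stands to compound 3: the change is hydrogen in place of chloro on an aromatic carbon, the same change as from compound 3 to compound 1, made at the same place. The step from compound 2 to compound 4 is expected to be an at least 12-fold lower number from compound 2 to compound 4 (1.09 log units; beyond the scatter), resting on the measured pair in which the same change gave a 95-fold lower number from compound 3 to compound 1 (1.98 log units; beyond the scatter). On that basis compound 4 is expected to give about 8000 nM in this assay. The estimated range for compound 4 runs from 1000 nM to 100000 nM. That range is wide. Compound 2 is known only as a limit, so the starting point of the step is itself uncertain, and the chance remains that compound 4 also returns only a limit.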

Compound 4, half-maximal inhibitory concentration: 960 nM
The estimate for compound 4 lay 8.3-fold (0.92 log units) above the measured number; the measured number lies below the stated range.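

In this assay, hydrogen in place of chloro on an aromatic carbon brings an at least 100-fold lower number from compound 2 to compound 4 (2.01 log units; beyond the scatter), so the change carries over from the core of compound 1 to the core of compound 4 in the same direction and remains large. Set side by side, the two steps read as follows: the same change on two cores in this assay, a 95-fold lower number (1.98 log units; beyond the scatter) from compound 3 to compound 1 and an at least 100-fold lower number (2.01 log units; beyond the scatter) from compound 2 to compound 4; the limit leaves it open whether they differ Compound 2 gives > 100000 nM, which is a limit of the assay and not a number, and these two cores are the only ones shown, so the steps show no exact size for the second core and nothing about any other core in the series.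

Only chloro and hydrogen appear at this place among the compounds shown, which leaves open whether fluoro, methoxy or an amine there would read closer to the chloro compounds or to the hydrogen compounds. Going by these compounds, it also remains open how a carboxylic acid in place of the methyl ester groups of compound 1 would read in this assay, and whether the chloro-to-hydrogen step would hold on such a core.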